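Chloro for Methyl on a Shared Fused Core

The source may report more compounds than this note shows. Statements on the series, on what has been measured and on what is new or still open speak of the compounds shown alone.

Measured compounds:
compound 1, `CCn1cc(C(=O)O)c(=O)c2cc(F)c(N3CCN(CN4C(=O)/C(=N\NC(=S)NO)c5cc(C)ccc54)C(C)C3)c(F)c21`, gives 244000 nM in an ADME assay on MT4 cells (Homo sapiens) for cytotoxicity, read by spectrophotometry, with a stated time of 5 days; a lower number here means that less compound is tolerated, a higher number that more compound is tolerated;
compound 2, `Cc1ccc2c(c1)/C(=N/NC(=S)NO)C(=O)N2CN1CCN(c2ccccc2)CC1`, gives 420000 nM in this assay;
compound 3, `O=C1/C(=N\NC(=S)NO)c2cc(Cl)ccc2N1CN1CCN(c2ccccc2)CC1`, gives 273000 nM in this assay.

Compounds 2 and 3 share one core and differ in a single place: chloro in place of methyl on an aromatic carbon. In this assay that change made a 1.5-fold lower number from compound 2 to compound 3 (0.19 log units; within the scatter), a step that stays within the scatter of repeated measurements. Compound 1 carries the same fused core as compound 2 joined to a larger remaining part; the difference between the two cores is not broken down here. The values of compounds 1, 2 and 3 all lie within the scatter of one another, so no order among them can be read from these three numbers.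

Compound 4, `CCn1cc(C(=O)O)c(=O)c2cc(F)c(N3CCN(CN4C(=O)/C(=N\NC(=S)NO)c5cc(Cl)ccc54)C(C)C3)c(F)c21`, has not yet been measured in this assay. It differs from compound 1 in one place only: chloro in place of methyl on an aromatic carbon. The leaving group, the entering group and the place are the same as in the pair of compounds 2 and 3, so this is the same change made on a larger molecule.

Because the earlier instance of this change gave a 1.5-fold lower number from compound 2 to compound 3 (0.19 log units; within the scatter), a small step of about the same size is expected here, and the step from compound 1 to compound 4 in this assay is estimated as a 1.4-fold lower number from compound 1 to compound 4 (0.13 log units; within the scatter). Compound 4 is therefore expected to give about 180000 nM in this assay, with the estimate spanning from 90000 nM to 360000 nM.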

Compound 4, half-maximal cytotoxic concentration: 209000 nM
For compound 4 the middle estimate is 1.2-fold (0.06 log units) below the measured one; the measured number falls inside the stated range.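

In this assay, chloro in place of methyl on an aromatic carbon gave a 1.2-fold lower number from compound 1 to compound 4 (0.07 log units; within the scatter), so on the larger molecule the change again stays within the scatter of repeated measurements. Set beside the earlier instance, the two steps cannot be told apart: the same change on two cores in this assay, a 1.5-fold lower number (0.19 log units; within the scatter) from compound 2 to compound 3 and a 1.2-fold lower number (0.07 log units; within the scatter) from compound 1 to compound 4, 1.3-fold (0.12 log units) apart, within the scatter of two such steps

This shows that, on these two cores, the change carried over without any step that can be read beyond the scatter, and that the larger remaining part of compound 1 and compound 4 brought no visible difference to it; it does not show that chloro truly gives a lower number than methyl, since neither step is large enough to support an order, and two pairs cannot establish a rule for the whole series.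

The compounds shown leave open what other groups on the same aromatic carbon, such as bromo, methoxy or an amine, would give in this assay. They also leave open whether the swap of methyl for chloro would stay as small at another carbon of that six-membered aromatic ring, or on a core other than these two.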